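Moving the Bromine Around the Benzyl Ring: Cytotoxicity Outlook

This account rests on a few compounds, and the source may have more. Where it says the series, first, only, none or still open, it means among the compounds named here.

Compound 1 `Cc1cc(/C=C2\SC(=S)N(Cc3ccccc3)C2=O)c(C)n1-c1ccc(O)c(C(=O)O)c1` gives 159000 nM in an ADME assay on MT2 cells (Homo sapiens) for cytotoxicity, read by XTT assay, with a stated time of 4 days; on this read-out lower numbers stand for higher toxicity in this test and higher numbers for lower toxicity in this test.
Compound 2 `Cc1cc(/C=C2\SC(=S)N(Cc3ccc(Br)cc3)C2=O)c(C)n1-c1ccc(O)c(C(=O)O)c1` gives 94400 nM in this assay.
Compound 3 `COC(=O)c1ccc(CN2C(=O)/C(=C/c3cc(C)n(-c4ccc(O)c(C(=O)O)c4)c3C)SC2=S)cc1` gives 36900 nM in this assay.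

Compound 2 stands second highest of these three numbers: its nearest neighbour is compound 1, with a 1.7-fold lower number from compound 1 to compound 2 (0.23 log units; within the scatter), and its furthest is compound 3, with a 2.6-fold lower number from compound 2 to compound 3 (0.41 log units; beyond the scatter). Compound 4 `Cc1cc(/C=C2\SC(=S)N(Cc3cccc(Br)c3)C2=O)c(C)n1-c1ccc(O)c(C(=O)O)c1` differs from compound 2 by 3-bromophenyl in place of 4-bromophenyl on a saturated chain carbon bound to an amide-type nitrogen in a ring. Going by the values given here, every measured step exchanges one group for another on that ring (a 1.7-fold lower number from compound 1 to compound 2 (0.23 log units; within the scatter), a 4.3-fold lower number from compound 1 to compound 3 (0.63 log units; beyond the scatter), a 2.6-fold lower number from compound 2 to compound 3 (0.41 log units; beyond the scatter)); none moves the same group to another position, so no step bears directly on this change. The expectation in this assay is therefore no step beyond the scatter, a 1.0-fold lower number from compound 2 to compound 4 (0.00 log units; within the scatter). Compound 4 is estimated at 94000 nM, within 40000 nM to 220000 nM.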

Compound 4, half-maximal cytotoxic concentration: 48200 nM
Compound 4: the middle estimate sits 2.0-fold (0.29 log units) above what was measured, and the stated range covers the measured number.
By their numbers in this assay, from the lowest: compounds 3, 4, 2 and 1 (each within the scatter of the next, the first and the last beyond it).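

The swap of 4-bromophenyl for 3-bromophenyl gives a 2.0-fold lower number from compound 2 to compound 4 (0.29 log units; within the scatter) in this assay, so moving the bromine cannot be told apart from the scatter of repeated measurements here. Adding bromine as 3-bromophenyl gives a 3.3-fold lower number from compound 1 to compound 4 (0.52 log units; beyond the scatter) and so goes beyond the scatter, which the 4-bromophenyl step from compound 1 did not, although the 3-bromophenyl and 4-(methoxycarbonyl)phenyl groups show a 1.3-fold higher number from compound 3 to compound 4 (0.12 log units; within the scatter) and stay close. No measurement offered here explains these numbers. From the compounds shown here alone, what an amine or a carboxylic acid in place of the bromine would give remains open.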